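Adding a second chloro to a benzyl purine core

This account rests on a few compounds, and the source may have more. Where it says the series, first, only, none or still open, it means among the compounds named here.

Measured so far:
Compound 1, `ClCc1ccc(Cn2cnc3c(Cl)ncnc32)cc1`: 5490 nM
Compound 2, `ClCc1ccccc1Cn1cnc2c(Cl)nc(Cl)nc21`: 3020 nM
Compound 3, `ClCc1ccccc1Cn1cnc2ncnc(Cl)c21`: 4460 nM

In a functional assay on NCI/ADR-RES cells (Homo sapiens) for cytotoxicity, read by sulforhodamine B assay, with a stated time of 48 h (a lower number here means a stronger inhibitor of growth, a higher number a weaker inhibitor of growth), compound 1 gives 5490 nM. That is the highest of the three numbers, yet the gaps are small: compound 3 gives 4460 nM, within the scatter of compound 1, and compound 2 gives 3020 nM, also within the scatter. On these numbers the three compounds cannot be told apart.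

Compound 4, `ClCc1ccc(Cn2cnc3c(Cl)nc(Cl)nc32)cc1`, has not yet been measured in this assay. It differs from compound 1 in one place: chloro in place of hydrogen on an aromatic carbon. Compound 4 thus carries two chloro groups on the shared core, as compound 2 does, while compound 1 and compound 3 carry one. Compound 2 and compound 3 also differ in where the benzyl substituent sits, so their values give no isolated reading of the chloro addition alone; they simply show two numbers within the scatter of each other.

Within the data shown here, no measured pair isolates this change. The expectation is a small step from compound 1 to compound 4, downward if at all, not clearly beyond the scatter. The estimate for compound 4 in this assay is 3600 nM, within a range of 1200 nM to 11000 nM, which amounts to an expected step of a 1.5-fold lower number from compound 1 to compound 4 (0.18 log units; within the scatter).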

Compound 4, concentration for total growth inhibition: > 100000 nM
Compound 4: no number, only a limit (the forecaster's own chance of this, stated with the estimate: 5%); at least 27-fold (1.44 log units) between middle value and limit.
By their numbers in this assay, from the lowest: compounds 2, 3 and 1 (each within the scatter of the next). At a limit, above all of these: compound 4.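

Compound 4 gives no number in this assay, only a limit: the limit of > 100000 nM in this assay, at which 1 of the 4 values shown sits.

Placing chloro in place of hydrogen on an aromatic carbon between two ring nitrogen atoms gives an at least 18-fold higher number from compound 1 to compound 4 (1.26 log units; beyond the scatter), so a change of one heavy atom at this position can take a compound from a measurable concentration for total growth inhibition to a limit. Compound 2 carries the same two chloro groups on the shared core and still gives 3020 nM, although it differs from compound 4 in where the benzyl substituent sits, so the second chloro does not bring this loss in every compound shown.

The compounds shown leave open whether this step belongs to chloro itself or would follow from any group at this carbon, a question that an amine or a methoxy group in the same place could address. They also leave open why the second chloro has so large an effect with one placement of the benzyl substituent and not with the other, since nothing here gives a cause.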